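A few compounds are considered here, and "the series" means these few. Any claim that something is new, unique, unknown or untested is made for them only; others in the source may bear on it.

Measured in a functional assay on A549 cells (Homo sapiens) for inhibition; on this read-out lower numbers stand for stronger inhibition and higher numbers for weaker inhibition:
- compound 1 `O=C(CC(CC(=O)NC1Cc2ccccc2C1)c1ccc(Cl)cc1)NCCN1CCCC1`: 50900 nM
- compound 2 `O=C(CC(CC(=O)NC1Cc2ccccc2C1)c1ccccc1)NCCN1CCCCC1`: > 100000 nM

The value of compound 2, > 100000 nM, is a limit of the assay and not a number. Compound 3 `O=C(CC(CC(=O)NC1Cc2ccccc2C1)c1ccccc1)NCCN1CCCC1` carries pyrrolidin-1-yl in place of piperidin-1-yl on a saturated chain carbon, two bonds along the chain from an amide-type nitrogen. Compound 1 also carries pyrrolidin-1-yl, differs elsewhere on the core, and gives 50900 nM, so only a modest move towards stronger inhibition is expected in this assay. The expected size of the move is an at least 1.2-fold lower number from compound 2 to compound 3 (0.09 log units; that floor lies within the scatter). For compound 3 the estimated value is 80000 nM, with an expected range of 45000 nM to 140000 nM.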

Compound 3, half-maximal inhibitory concentration: > 100000 nM
Compound 3 gave a limit, no number; the forecaster's own chance of this, stated with the estimate: 45%; middle value at least 1.2-fold (0.09 log units) from the limit.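

In this assay, the change from piperidin-1-yl to pyrrolidin-1-yl on a saturated chain carbon, two bonds along the chain from an amide-type nitrogen, cannot be read, since compound 2 and compound 3 both end at a limit: the limit of > 100000 nM in this assay, at which 2 of the 3 values shown sit. With pyrrolidin-1-yl held constant, hydrogen in place of chloro on an aromatic carbon gives an at least 1.9-fold higher number from compound 1 to compound 3 (0.29 log units; that floor lies within the scatter), so any contribution of chloro remains unconfirmed.

Any difference between the two rings on the chain remains open without a measurable value on both sides. Also open, going by these compounds, is how morpholin-4-yl or dimethylamino would read at this position, particularly with chloro retained on the aromatic carbon.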